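Swapping Sulfur for Selenium on Two Different Cores

A few compounds are considered here, and "the series" means these few. Any claim that something is new, unique, unknown or untested is made for them only; others in the source may bear on it.

Compound 2 `CS/C(=N\C(=O)c1cccs1)NC(=O)c1cccs1` and compound 1 `C[Se]/C(=N\C(=O)c1cccs1)NC(=O)c1cccs1` share one core. In an ADME assay on MCF-10A cells (Homo sapiens) for cytotoxicity, read by MTT assay, with a stated time of 72 h (a lower number here means a stronger inhibitor of growth, a higher number a weaker inhibitor of growth), compound 2 gives 55100 nM, and compound 1 gives 41100 nM. Among the compounds with values here, the only change between them is a group of 2 heavy atoms (1 carbon, 1 selenium; no ring) in place of a group of 2 heavy atoms (1 carbon, 1 sulfur; no ring), on a carbon with a double bond to nitrogen, and the step it made was a 1.3-fold lower number from compound 2 to compound 1 (0.13 log units; within the scatter).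

Compound 3 `CS/C(=N\C(=O)c1cc(-c2ccccc2)nc2ccccc12)NC(=O)c1cc(-c2ccccc2)nc2ccccc12` carries a different core; how the two cores differ is not broken down here. In this assay compound 3 gives 540 nM, the lowest of the three numbers, beyond the scatter from both compound 1 and compound 2.

Compound 4 `C[Se]/C(=N\C(=O)c1cc(-c2ccccc2)nc2ccccc12)NC(=O)c1cc(-c2ccccc2)nc2ccccc12` has not yet been measured. It differs from compound 3 by a group of 2 heavy atoms (1 carbon, 1 selenium; no ring) in place of a group of 2 heavy atoms (1 carbon, 1 sulfur; no ring), on a carbon with a double bond to nitrogen, the same change that separates compound 2 from compound 1, at a place described in the same words.

Because the earlier step of a 1.3-fold lower number from compound 2 to compound 1 (0.13 log units; within the scatter) stayed within the scatter, the matching step on the new core is expected to be small as well, about a 1.2-fold lower number from compound 3 to compound 4 (0.08 log units; within the scatter). Compound 4 is therefore estimated at 450 nM, with a likely range from 200 nM to 1100 nM. Within the data shown here, only one earlier example of this change exists, on another core, so the estimate carries real uncertainty.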

Compound 4, concentration for total growth inhibition: 20100 nM
Compound 4: the middle estimate sits 45-fold (1.65 log units) below what was measured; measured number above the stated range.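

Within the data shown here, on the second core, putting the selenium group in place of methylsulfanyl produced a 37-fold higher number from compound 3 to compound 4 (1.57 log units; beyond the scatter) in this assay, which means a much weaker inhibitor of growth, whereas the same swap on the first core made no change beyond the scatter. Among these compounds, the size of this swap's effect therefore depends on the core that carries it, at least for these two cores: the same change on two cores in this assay, a 1.3-fold lower number (0.13 log units; within the scatter) from compound 2 to compound 1 and a 37-fold higher number (1.57 log units; beyond the scatter) from compound 3 to compound 4, 50-fold (1.70 log units) apart, beyond the scatter of two such steps This shows that a small step on one core gave no safe guide to the step on the other, but with only two pairs it does not show which part of the cores is responsible, why the outcomes part, or what would happen on a third core.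

The compounds shown leave open how the two cores would respond to other groups on a carbon with a double bond to nitrogen, such as an ethyl chain on the sulfur or selenium, or an amine in place of either group. They also leave open whether the large step on the second core would appear in other cell types.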